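The source may hold more compounds than are shown below. What is called first, only, known or untested is meant among the compounds shown, and "the series" means these compounds.

Three compounds share one core and differ only at its far end, and all were tested in an assay on isolated protein for inhibition of tyrosine-protein kinase receptor UFO (Homo sapiens), read by FRET and Z'-LYTE, with a stated time of 1.5 h; a lower number here means a stronger inhibitor, a higher number a weaker inhibitor. Compound 1 `Cc1ccc2c(c1)c(=O)c(C(=O)Nc1ccc(Oc3ncnc4[nH]cc(-c5ccccc5)c34)c(F)c1)c(C)n2C` gives 100 nM, compound 2 `CCc1ccc2c(c1)c(=O)c(C(=O)Nc1ccc(Oc3ncnc4[nH]cc(-c5ccccc5)c34)c(F)c1)c(C)n2C` gives 6 nM, and compound 3 `CCc1ccc2c(c1)c(=O)c(C(=O)Nc1ccc(Oc3ncnc4[nH]ccc34)c(F)c1)c(C)n2C` gives 157 nM, the highest of the three numbers. Against compound 1 the gap is within the scatter; against compound 2 it is not, as the step of a 26-fold higher number from compound 2 to compound 3 (1.42 log units; beyond the scatter) shows. The other step, a 17-fold lower number from compound 1 to compound 2 (1.22 log units; beyond the scatter), is also large and lies at the opposite end of the molecule.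

Compound 4 `CCc1ccc2c(c1)c(=O)c(C(=O)Nc1ccc(Oc3ccnc(N)c3)c(F)c1)c(C)n2C` moves from compound 3 by a group of 7 heavy atoms (5 carbon, 2 nitrogen; one six-membered aromatic ring with 1 hetero atom) in place of a group of 9 heavy atoms (6 carbon, 3 nitrogen; one five-membered aromatic ring with 1 hetero atom, one six-membered aromatic ring with 2 hetero atoms), on an oxygen on an aromatic ring. Among the measured compounds shown here, no measured pair exchanges this whole group, so the only guide is that the step of a 26-fold higher number from compound 2 to compound 3 (1.42 log units; beyond the scatter) proves changes at this position can be large. On that basis a step of uncertain direction is expected, a 1.9-fold higher number from compound 3 to compound 4 (0.28 log units; within the scatter), and for compound 4 a value of about 300 nM is estimated in this assay, somewhere between 60 nM and 2000 nM.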

Compound 4, half-maximal inhibitory concentration: 888 nM
Compound 4: middle estimate off by 3.0-fold (0.47 log units), on the low side, within the range that was stated.
By their numbers in this assay, from the lowest: compound 2; then compounds 1 and 3 (each within the scatter of the next); then compound 4.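

Among the compounds shown here, until now, the only change at this end of the molecule was the loss of a phenyl group. Here the whole group on the oxygen is exchanged, and the result is a 5.7-fold higher number from compound 3 to compound 4 (0.75 log units; beyond the scatter), so the group itself matters even when no phenyl is attached. The entering 2-aminopyridin-4-yl has fewer heavy atoms and one ring instead of two, yet the same counts of hydrogen-bond donors and acceptors as the group it replaces, and no measurement at hand explains the weaker result.

As far as these compounds go, it remains open whether the amine of the 2-aminopyridin-4-yl contributes at all, which a plain pyridin-4-yl would test. An acetamide or a methylamine in place of that amine would show whether this spot tolerates anything larger.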